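Benzyl esters of a dienoate and trienoate phenol series

A few compounds are considered here, and "the series" means these few. Any claim that something is new, unique, unknown or untested is made for them only; others in the source may bear on it.

The shared core carries a phenol on an alkenyl chain and an unsaturated ester. Compound 1 is `C=C[C@@](C)(/C=C/c1ccc(O)cc1)CC/C=C/C(=O)OCC`, compound 2 is `C=C[C@@](C)(/C=C/c1ccc(O)cc1)CC/C=C/C(=O)OCc1ccccc1`, and compound 3 is `C=C[C@@](C)(/C=C/c1ccc(O)cc1)CC/C=C(C)/C=C/C(=O)OCC`, whose core differs from that of compound 1 in a way not broken down here. Compound 4, not yet measured, is `C=C[C@@](C)(/C=C/c1ccc(O)cc1)CC/C=C(C)/C=C/C(=O)OCc1ccccc1`. In an ADME assay on BJ cells (Homo sapiens) for cytotoxicity, with a stated time of 72 h (a lower number here means that less compound is needed, a higher number that more compound is needed for the effect), compound 1 gives > 36600 nM, a limit of the assay. Compound 2 gives > 36600 nM in this assay, again a limit. Compound 3 likewise gives > 36600 nM, a limit. The change from compound 1 to compound 2 is phenyl in place of methyl on a saturated chain carbon bound to an oxygen next to a carbonyl group, and the step is a step that the two limits leave unreadable from compound 1 to compound 2. The change from compound 3 to compound 4 is the same kind of change, (phenyl in place of methyl on a saturated chain carbon bound to an oxygen next to a carbonyl group), at the same place. Going by the values given here, because of the limit of > 36600 nM in this assay, at which 3 of the 3 values shown sit, no measured step in this assay is readable. The step from compound 3 to compound 4 is expected to be a step that the limit leaves unreadable from compound 3 to compound 4, resting on the unreadable step between compound 1 and compound 2. Compound 4 is thus estimated at 50000 nM in this assay, in a range from 18000 nM to 200000 nM.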

Compound 4, half-maximal effective concentration: > 36600 nM
Compound 4 ended at the assay's limit (the forecaster's own chance of this, stated with the estimate: 85%); the middle value does not contradict the limit.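

The step from compound 3 to compound 4 cannot be read in this assay, since both compounds sit at the same limit of the assay: the limit of > 36600 nM in this assay, at which 4 of the 4 values shown sit.

The compounds shown leave open what half-maximal effective concentration any of them has in this assay, and so whether ethoxycarbonyl to benzyloxycarbonyl changes that read-out at all.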